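Replacing pyrrolidin-1-yl with phenyl at one aromatic carbon

This account rests on a few compounds, and the source may have more. Where it says the series, first, only, none or still open, it means among the compounds named here.

Three compounds share one core and differ only in the group on an aromatic carbon. In a functional assay on U-251 cells (Homo sapiens) for inhibition, read by sulforhodamine B assay, with a stated time of 72 h (on this read-out higher numbers stand for an effect only at larger amounts of compound and lower numbers for an effect already at smaller amounts), compound 1 `O=C(/C=C/c1ccc([N+](=O)[O-])o1)c1ccc(I)cc1` gives 12500 nM. Compound 2 `O=C(/C=C/c1ccc([N+](=O)[O-])o1)c1ccc(-n2ccnc2)cc1` gives 22600 nM, and compound 3 `O=C(/C=C/c1ccc([N+](=O)[O-])o1)c1ccc(N2CCCC2)cc1` gives 35900 nM. Compound 3 stands at the upper end of this small set. It sits level with compound 2, with a 1.6-fold higher number from compound 2 to compound 3 (0.20 log units; within the scatter), and apart from compound 1, with a 2.9-fold higher number from compound 1 to compound 3 (0.46 log units; beyond the scatter).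

Compound 4 `O=C(/C=C/c1ccc([N+](=O)[O-])o1)c1ccc(-c2ccccc2)cc1` has not yet been measured. It carries phenyl in place of pyrrolidin-1-yl on an aromatic carbon, para to a large group: phenyl in place of pyrrolidin-1-yl on an aromatic carbon.

The measured steps at this same place are the guide. Besides the two above, there is a 1.8-fold higher number from compound 1 to compound 2 (0.26 log units; within the scatter). None of them is more than modest, so only a small step is expected here. With compound 3 at the upper end, the expectation leans towards a lower number, although three compounds are a thin basis. The estimated change is a 1.8-fold lower number from compound 3 to compound 4 (0.25 log units; within the scatter), so no shift beyond the scatter is expected. The estimated value for compound 4 is 20000 nM, with an expected range of 8000 nM to 42000 nM.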

Compound 4, half-maximal effective concentration: 24600 nM
Estimate against measurement, compound 4: 1.2-fold (0.09 log units) below; the range from low to high includes it.
By their numbers in this assay, from the lowest: compounds 1, 2, 4 and 3 (each within the scatter of the next, the first and the last beyond it).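

In this assay, phenyl at this aromatic carbon cannot be told apart from pyrrolidin-1-yl (a 1.5-fold lower number from compound 3 to compound 4 (0.16 log units; within the scatter)) or from 1H-imidazol-1-yl (a 1.1-fold higher number from compound 2 to compound 4 (0.04 log units; within the scatter)), so for this pair of groups, swapping a non-aromatic ring with a hydrogen-bond acceptor for an all-carbon aromatic ring without one changes nothing that can be read. The step from iodo is also within the scatter (a 2.0-fold higher number from compound 1 to compound 4 (0.29 log units; within the scatter)), so compound 4 cannot be set apart from any of the other three, even though compound 1 and compound 3 do differ by more than the scatter, which suggests a gradual spread across these groups rather than two separate classes. No independent measurement is available that bears on this result.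

On these data alone, whether an amine, a carboxylic acid or a longer alkyl chain on this aromatic carbon would move the number beyond the scatter remains open. As far as these compounds go, with all four compounds lying so close together, it is also open whether the group at this place has much influence on this read-out at all, or whether the shared core sets most of the effect.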